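A few compounds are considered here, and "the series" means these few. Any claim that something is new, unique, unknown or untested is made for them only; others in the source may bear on it.

Compound 1 `CNC(=O)c1cc(C(=O)N[C@H]2[C@@H]3COC[C@@H]32)cc2c1OC[C@H]2c1cccnc1` is measured in a physicochemical assay for solubility; on this read-out lower numbers stand for lower solubility and higher numbers for higher solubility. For compound 1 the read-out of >= 104 ug/mL is a limit of the assay rather than a number, so compound 1 stands at the limit of >= 104 ug/mL in this assay, at which 1 of the 3 values shown sits, and its true solubility is not pinned down. Two further compounds sit beside it. Compound 2 `CC[C@@]1(c2ccccc2)COc2c(C(=O)NC)cc(C(=O)N[C@H]3[C@@H]4COC[C@@H]43)cc21` also returns a limit, >= 152 ug/mL, which places it at the limit of >= 152 ug/mL in this assay, at which 1 of the 3 values shown sits. Compound 3 `CNC(=O)c1cc(C(=O)NCCC[C@H]2OC[C@H](N)CO2)cc2c1O[C@H](CF)[C@H]2c1ccccc1` gives a plain number in this assay, 174 ug/mL. Among the three values, only compound 3 is a measured figure; the other two are limits, so no ordering among them can be read.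

Compound 4 `CNC(=O)c1cc(C(=O)N[C@H]2[C@@H]3COC[C@@H]32)cc2c1OC[C@H]2c1ccccc1C` has not yet been measured. It differs from compound 1 in one place: 2-methylphenyl in place of pyridin-3-yl on a saturated ring carbon. Among the compounds with values here, no measured pair in this set carries that change, so the expectation rests on the structures alone. The step of an at least 2.6-fold lower number from compound 1 to compound 4 (0.41 log units; beyond the scatter) is expected to run downward, beyond the usual scatter. Compound 4 is therefore estimated at 40 ug/mL, with a plausible span from 10 ug/mL to 120 ug/mL.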

Compound 4, solubility: >= 103 ug/mL
Compound 4 ended at the assay's limit (the forecaster's own chance of this, stated with the estimate: 25%); at least 2.5-fold (0.41 log units) between middle value and limit.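

Within the data shown here, compound 1 and compound 4 both return a limit in this assay, so no step between the two can be read. The compounds shown leave open where either true value lies, and whether 2-methylphenyl in place of pyridin-3-yl shifts the read-out at all.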